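The source may hold more compounds than are shown below. What is called first, only, known or untested is meant among the compounds shown, and "the series" means these compounds.

Among the measured compounds shown here, in a functional assay on SMOV2 cells (Homo sapiens) for antiproliferative activity, read by sulforhodamine B assay, with a stated time of 5 days (a higher number here means a weaker inhibitor of growth, a lower number a stronger inhibitor of growth), compound 1 (`O=c1[nH]c2ccc(-c3csc(-c4ccccc4)n3)cc2o1`) gives 2000 nM and compound 2 (`O=c1[nH]c2ccc(-c3csc(-c4ccc(Cl)cc4)n3)cc2o1`) gives 630 nM, the lower of the two numbers so far. Compound 3 (`N#Cc1ccc(-c2nc(-c3ccc4[nH]c(=O)oc4c3)cs2)cc1`) is not yet measured and has cyano in place of chloro on an aromatic carbon, para to a large group: cyano in place of chloro on an aromatic carbon. For the measured compounds named here, only one measured step bears on this place: a 3.2-fold lower number from compound 1 to compound 2 (0.50 log units; beyond the scatter), a modest step with chloro in place of hydrogen. Going by the values given here, no measured compound carries cyano, so the data do not show how it compares with chloro. A large move in either direction is therefore not expected, and the series offers no firm basis for one. The expected change is a 1.3-fold higher number from compound 2 to compound 3 (0.10 log units; within the scatter), with no shift beyond the scatter anticipated. For compound 3 the estimated value is 800 nM, with an expected range of 250 nM to 2500 nM.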

Compound 3, concentration for 50% growth inhibition: 2000 nM
For compound 3 the middle estimate is 2.5-fold (0.40 log units) below the measured one, and the stated range covers the measured number.
By their numbers in this assay, from the lowest: compound 2; then compounds 1 and 3 (each within the scatter of the next).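

At this aromatic carbon, para to a large group, the lower number seen with chloro does not carry over to cyano in this assay (a 3.2-fold higher number from compound 2 to compound 3 (0.50 log units; beyond the scatter)). Cyano and hydrogen are not told apart here (no change at the digits printed from compound 1 to compound 3 (within the scatter)), so among these three compounds only chloro stands apart, and a substituent at this place does not by itself lower the number. Nothing available bears on why chloro differs from cyano.

The compounds shown leave open whether chloro is a single case or whether groups such as bromo, methyl or methoxy at the same place also lower the number. They also leave open how an amine or a carboxylic acid would read here, and whether the chloro step holds at other carbons of this ring.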